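The source may hold more compounds than are shown below. What is called first, only, known or untested is meant among the compounds shown, and "the series" means these compounds.

Measured compounds:
Compound 1, `CCC(=O)c1ccc(OCCCCOc2ccc(F)c(C(=O)O)c2)c(C)c1O`: 96%
Compound 2, `COc1ccc(C(=O)O)cc1OCCCCOc1ccc(C(=O)CC2CCCC2)c(O)c1C`: 103%

In an ADME assay on a cell-free system (plasma, Rattus norvegicus) for metabolic stability, read by LC-MS, with a stated time of 60 min, tested at 100 uM (a lower number here means that less of the compound is left, a higher number that more of the compound is left), compound 1 gives 96%. Compound 2 gives 103%. The gap between these two numbers lies within the usual scatter, so compound 1 stands level with compound 2, and both are nearly unchanged after the stated time.

Compound 3 `Cc1c(OCCCCOc2ccc(F)c(C(=O)O)c2)ccc(C(=O)CC(C)C)c1O` differs from compound 1 by isopropyl in place of methyl on a saturated chain carbon bound to a carbonyl carbon.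

Among the compounds with values here, no step between measured compounds is available to set a size. Since both measured compounds are essentially intact, the expected step from compound 1 to compound 3 in this assay is a number 1 percentage points higher from compound 1 to compound 3 (within the scatter), that is, none beyond the scatter. Compound 3 is estimated at 97%, in a range from 85% to 108%.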

Compound 3, percent of the compound remaining: 101%
Compound 3: the middle estimate sits 4 percentage points below what was measured; measured number inside the range.
By their numbers in this assay, from the lowest: compounds 1, 3 and 2 (each within the scatter of the next).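

In this assay, isopropyl in place of methyl on a saturated chain carbon bound to a carbonyl carbon gives a number 5 percentage points higher from compound 1 to compound 3 (within the scatter). This first direct pair shows that, at this position, the bulkier isopropyl and the smaller methyl cannot be told apart in how much compound is left. Nothing measured here explains this result. The compounds shown leave open whether an amine or a hydroxyl group on this same chain carbon would give a number level with these in this assay. They also leave open whether a much longer chain would do so.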